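Aryl ether exchange at compound 4: expected cytotoxicity

This account rests on a few compounds, and the source may have more. Where it says the series, first, only, none or still open, it means among the compounds named here.

Three compounds carry a result in an ADME assay on PBMC cells (Homo sapiens) for cytotoxicity; a higher number here means that more compound is tolerated, a lower number that less compound is tolerated. Compound 1 `CCO/N=C(/c1ccc(Br)cc1)C1CCN(C(C)(C)CCNC(=O)c2c(Cl)cncc2Cl)CC1` gives 34000 nM. Compound 2 `CC(CCNC(=O)c1c(Cl)cncc1Cl)N1CCC(C(Oc2cccc(F)c2)c2ccc(C(F)(F)F)cc2)CC1` gives 5400 nM, the lowest of the two numbers; the nearest number, that of compound 1, sits higher by a gap beyond the usual scatter. Compound 3 `CCO/N=C(/c1ccc(Br)cc1)C1CCN(C(CC)CCNC(=O)c2c(C)cc[n+]([O-])c2C)CC1` gives no number but only a limit, > 177000 nM; this is the limit of > 177000 nM in this assay, at which 1 of the 3 values shown sits.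

Compound 4 `CC(CCNC(=O)c1c(Cl)cncc1Cl)N1CCC(C(Oc2cc(Cl)ccn2)c2ccc(C(F)(F)F)cc2)CC1` awaits measurement in this assay. It differs from compound 2 in one place: 4-chloropyridin-2-yl in place of 3-fluorophenyl on an oxygen on a saturated carbon. Among the compounds with values here, no measured pair shows this change or one like it, so a step of no more than the usual scatter is expected, in either direction; the expected step from compound 2 to compound 4 is a 1.1-fold higher number from compound 2 to compound 4 (0.05 log units; within the scatter). Compound 4 is estimated at 6000 nM, between 2000 nM and 20000 nM.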

Compound 4, half-maximal cytotoxic concentration: 4260 nM
Compound 4: middle estimate off by 1.4-fold (0.15 log units), on the high side; low and high end bracket the measured number.
By their numbers in this assay, from the lowest: compounds 4 and 2 (each within the scatter of the next); then compound 1. At a limit, above all of these: compound 3.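

In this assay, the only step shown at this position, on an oxygen on a saturated carbon, is small: a 1.3-fold lower number from compound 2 to compound 4 (0.10 log units; within the scatter). Exchanging 3-fluorophenyl for 4-chloropyridin-2-yl, and so adding a ring nitrogen and a hydrogen-bond acceptor, thus leaves the two numbers within the scatter of each other. Nothing measured for these compounds bears on this result.

As far as these compounds go, whether a carboxylic acid, an amine or a longer alkyl chain at this oxygen would give a step beyond the scatter remains open. From the compounds shown here alone, this exchange also rests on a single pair, so its size on other cores is unknown.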